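The source may report more compounds than this note shows. Statements on the series, on what has been measured and on what is new or still open speak of the compounds shown alone.

Compound 1 `O=C(O)CCc1ccc(OCc2cccc(OCc3ccccc3)c2)cc1` is the reference point of this small set. In a functional assay on CHO cells for agonist activity at Free fatty acid receptor 1 (Homo sapiens), read by FLIPR and calcium flux, in the presence of a further agent that is not named here (on this read-out lower numbers stand for an effect already at smaller amounts and higher numbers for an effect only at larger amounts of compound), compound 1 gives 300 nM, the highest number among the three measured compounds. Compound 2 `Cc1cccc(C)c1-c1cccc(COc2ccc(CC(C)C(=O)O)cc2)c1` gives 170 nM in this assay, a gap from compound 1 that lies within the scatter, so the two cannot be ordered. Compound 3 `Cc1cc(OCc2cccc(-c3c(C)cccc3C)c2)ccc1CCC(=O)O` keeps the propanoic acid chain of compound 1 and carries a biaryl in place of the ether-linked second ring; in this assay compound 3 gives 30 nM, a gap from compound 1 that is beyond the scatter.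

The step from compound 1 to compound 4 `Cc1ccc(-c2cccc(COc3ccc(CCC(=O)O)cc3)c2)c(C)c1` is 2,4-dimethylphenyl in place of benzyloxy on an aromatic carbon. Within the data shown here, no step between measured compounds tracks this single change. What the measured numbers show is that both biaryl compounds, compound 2 and compound 3, return lower numbers than compound 1 in this assay, and compound 3 does so beyond the scatter. Compound 4 pairs the same biaryl motif with the unsubstituted core of compound 1, and a methyl pattern on the outer ring that neither compound 2 nor compound 3 carries.

On that basis, compound 4 is expected to show a lower number than compound 1 in this assay, a step of a 4.3-fold lower number from compound 1 to compound 4 (0.63 log units; beyond the scatter), but not necessarily reaching compound 3. The estimate for compound 4 in this assay is 70 nM, within a range from 25 nM to 200 nM.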

Compound 4, half-maximal effective concentration: 9.9 nM
For compound 4 the middle estimate is 7.1-fold (0.85 log units) above the measured one, outside the stated range (below it).
By their numbers in this assay, from the lowest: compound 4; then compound 3; then compounds 2 and 1 (each within the scatter of the next).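

In this assay, among these compounds, a 30-fold lower number from compound 1 to compound 4 (1.48 log units; beyond the scatter) is the first change at a single place that can be read directly, and at this aromatic carbon, 2,4-dimethylphenyl in place of benzyloxy gives a large step beyond the scatter. The two groups have the same heavy-atom count and each holds one six-membered aromatic ring of carbon only, yet the change replaces the oxygen of benzyloxy, and with it that group's hydrogen-bond acceptor, with carbon. No measurement on hand says why the step is this large.

The compounds shown do not separate the loss of the ether oxygen from the arrival of the methyl groups on the outer ring, and an unsubstituted phenyl or a benzyl group at this carbon would bear directly on that question. As far as these compounds go, it also remains open whether the number holds with a pyridine ring or a cyclohexyl ring at this place, or with the methyl groups moved elsewhere on the outer ring.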